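Swapping the urea aryl group: from ethynylphenyl to sulfonamide

A few compounds are considered here, and "the series" means these few. Any claim that something is new, unique, unknown or untested is made for them only; others in the source may bear on it.

Measured compounds in a functional assay on MDA-MB-231 cells (Homo sapiens) for antiproliferative activity, read by MTT assay, with a stated time of 72 h; a higher number here means a weaker inhibitor, a lower number a stronger inhibitor:
- compound 1, `Cc1ccc(NC(=O)Nc2cccc(-c3nc(-c4ccc(NC(=O)c5cccnc5)cc4Cl)no3)c2)cc1`, gives 3500 nM
- compound 2, `COc1ccc(NC(=O)Nc2cccc(-c3nc(-c4ccc(NC(=O)c5cccnc5)cc4Cl)no3)c2)cc1C(F)(F)F`, gives 1700 nM
- compound 3, `C#Cc1ccc(NC(=O)Nc2cccc(-c3nc(-c4ccc(NC(=O)c5cccnc5)cc4Cl)no3)c2)cc1`, gives > 10000 nM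

For compound 3 the value is a limit of the assay, not a number, so compound 3 stands at the weak end of what was measured (the limit of > 10000 nM in this assay, at which 1 of the 3 values shown sits). The unmeasured compound 4 is `CS(=O)(=O)Nc1ccc(NC(=O)Nc2cccc(-c3nc(-c4ccc(NC(=O)c5cccnc5)cc4Cl)no3)c2)cc1Cl`; it differs from compound 3 by 3-chloro-4-(methanesulfonamido)phenyl in place of 4-ethynylphenyl on an amide-type nitrogen.

Among the measured compounds shown here, two measured steps bear on this change, since both move between differently substituted phenyl groups on the same urea nitrogen. The step of a 2.1-fold lower number from compound 1 to compound 2 (0.31 log units; beyond the scatter) and the step of an at least 5.8-fold higher number from compound 2 to compound 3 (0.76 log units; beyond the scatter) together show that the ethynylphenyl compound sits above the other two, while the step of an at least 2.8-fold higher number from compound 1 to compound 3 (0.45 log units; beyond the scatter) points the same way. Leaving the ethynylphenyl for a substituted phenyl is therefore expected to bring the number down again, into the region of compound 1 and compound 2, giving an expected step of an at least 3.3-fold lower number from compound 3 to compound 4 (0.52 log units; beyond the scatter). Compound 4 is thus estimated at 3000 nM, within a range from 1000 nM to 10000 nM.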

Compound 4, half-maximal inhibitory concentration: 600 nM
For compound 4 the middle estimate is 5.0-fold (0.70 log units) above the measured one, outside the stated range (below it).
By their numbers in this assay, from the lowest: compound 4; then compound 2; then compound 1. At a limit, above all of these: compound 3.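

In this assay, this place on the urea nitrogen accepts a larger group, with 12 heavy atoms against 8: 3-chloro-4-(methanesulfonamido)phenyl gives an at least 16-fold lower number from compound 3 to compound 4 (1.22 log units; beyond the scatter). The same group also improves on both earlier substituted phenyl groups, with a 2.8-fold lower number from compound 2 to compound 4 (0.45 log units; beyond the scatter) and a 5.8-fold lower number from compound 1 to compound 4 (0.77 log units; beyond the scatter), so compound 4 is the strongest of the four, not merely a return to the level of compound 1 and compound 2. The value of compound 3 is a limit, not a number: the limit of > 10000 nM in this assay, at which 1 of the 4 values shown sits.

Chlorine and methanesulfonamido enter together, so the compounds shown cannot tell how much of the gain belongs to each. From the compounds shown here alone, it also remains open how a primary amine or a carboxylic acid in the place of the methanesulfonamido group would compare.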